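Cyclopentyl for Isopropyl on the Ketone Side Chain

The source may report more compounds than this note shows. Statements on the series, on what has been measured and on what is new or still open speak of the compounds shown alone.

Of the compounds shown here, two have been measured in an assay on HEK293 cells for positive allosteric modulation of metabotropic glutamate receptor 2 (Rattus norvegicus), read by thallium flux, with a stated time of 2.5 min; on this read-out higher numbers stand for an effect only at larger amounts of compound and lower numbers for an effect already at smaller amounts. Compound 1 `Cc1c(OCCCCOc2ccc(C(=O)O)c(Cl)c2)ccc(C(=O)CC2CCCC2)c1O` gives 510 nM in this assay. Compound 2 `Cc1cc(OCCCCOc2ccc(C(=O)CC(C)C)c(O)c2C)ccc1C(=O)O` gives 173 nM in this assay, the lowest of the two numbers, and its nearest neighbour is compound 1, whose number lies higher by a gap beyond the scatter. Compound 1 and compound 2 differ in more than one place, so nothing is taken from that pair beyond what the two values show.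

Compound 3 `Cc1cc(OCCCCOc2ccc(C(=O)CC3CCCC3)c(O)c2C)ccc1C(=O)O` follows from compound 2 by a single change: cyclopentyl in place of isopropyl on a saturated chain carbon bound to a carbonyl carbon. For the measured compounds named here, no pair of measured compounds isolates this change. In this assay the step from compound 2 to compound 3 is expected to stay within the scatter, with no clear direction. Compound 3 is therefore expected to give 150 nM in this assay, within a range from 60 nM to 400 nM. The expected step is a 1.2-fold lower number from compound 2 to compound 3 (0.06 log units; within the scatter).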

Compound 3, half-maximal effective concentration: 564 nM
Estimate against measurement, compound 3: 3.8-fold (0.58 log units) below, and the stated range ends below it.
By their numbers in this assay, from the lowest: compound 2; then compounds 1 and 3 (each within the scatter of the next).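

In this assay, the position on a saturated chain carbon bound to a carbonyl carbon proves sensitive to this change: cyclopentyl in place of isopropyl gives a 3.3-fold higher number from compound 2 to compound 3 (0.51 log units; beyond the scatter), so the isopropyl group is the better of the two here. The new compound also isolates a second change, methyl in place of chloro on an aromatic carbon, which gives a 1.1-fold higher number from compound 1 to compound 3 (0.04 log units; within the scatter), so the two groups are not told apart with cyclopentyl on the chain. Nothing available on these compounds bears on why the chain change shifts the number.

The compounds shown leave open how a cyclobutyl, a phenyl or an unbranched propyl group would read at this place, and whether the step follows the ring or the added carbons. Also open, on these data alone, is whether methyl and chloro would remain level with isopropyl on the chain.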